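The source may report more compounds than this note shows. Statements on the series, on what has been measured and on what is new or still open speak of the compounds shown alone.

Measured compounds:
Compound 1, `COc1ccc2nc(-c3ccc(N/C=C\C(=O)c4cc(OC)c(OC)c(OC)c4)cc3)sc2c1`: 19600 nM
Compound 2, `COc1cc(C(=O)/C=C\Nc2ccc(-c3nc4cc(OC)c(OC)c(OC)c4s3)cc2C)c(Br)c(OC)c1OC`: 7300 nM
Compound 3, `COc1ccc2nc(-c3ccc(N/C=C\C(=O)c4cc(OC)c(OC)c(OC)c4Br)cc3)sc2c1`: 11100 nM

These three compounds were tested in a functional assay on MDA-MB-231 cells (Homo sapiens) for antiproliferative activity, read by sulforhodamine B assay, with a stated time of 48 h; on this read-out lower numbers stand for stronger inhibition and higher numbers for weaker inhibition. Compound 3 and compound 1 differ in one place, (hydrogen in place of bromo on an aromatic carbon), and that change gave a 1.8-fold higher number from compound 3 to compound 1 (0.25 log units; within the scatter). Compound 2 and compound 3 give numbers that lie within the scatter of each other, while compound 1 gives a number that lies beyond the scatter above that of compound 2. The difference between the core of compound 2 and the core of compound 3 is not broken down here.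

Compound 4, `COc1cc(C(=O)/C=C\Nc2ccc(-c3nc4cc(OC)c(OC)c(OC)c4s3)cc2C)cc(OC)c1OC`, has not yet been measured in this assay. It differs from compound 2 by hydrogen in place of bromo on an aromatic carbon. The surroundings of the place are described in the same words for both changes, so it is the same change made on a different core. Given a 1.8-fold higher number from compound 3 to compound 1 (0.25 log units; within the scatter), compound 4 is expected to show a step of a 1.8-fold higher number from compound 2 to compound 4 (0.25 log units; within the scatter). Compound 4 is therefore estimated at 13000 nM, with a likely range from 5500 nM to 30000 nM.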

Compound 4, half-maximal inhibitory concentration: 12900 nM
Compound 4: the middle estimate sits 1.0-fold (0.00 log units) above what was measured; measured number inside the range.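

In this assay, hydrogen in place of bromo on a second core gave a 1.8-fold higher number from compound 2 to compound 4 (0.25 log units; within the scatter). The change carried over from one core to the other with no detectable difference in the size of the step: the same change on two cores in this assay, a 1.8-fold higher number (0.25 log units; within the scatter) from compound 3 to compound 1 and a 1.8-fold higher number (0.25 log units; within the scatter) from compound 2 to compound 4, 1.0-fold (0.00 log units) apart, within the scatter of two such steps. Each step on its own lies within the scatter, however, so this agreement does not establish that the bromo group alters the number at all, and two cores are too few to say that the same step would appear elsewhere in the series.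

The compounds shown carry only bromo or hydrogen at this place, which leaves open how chloro, fluoro, a methyl group or a nitrile would read there. The cores also differ from each other in more than one feature, and these pairs cannot tell whether the methyl group or the extra methoxy groups of the core of compound 2 would shift the number when changed one at a time.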